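Pentafluorosulfanyl to trifluoromethyl swap across two series cores

A few compounds are considered here, and "the series" means these few. Any claim that something is new, unique, unknown or untested is made for them only; others in the source may bear on it.

Three compounds have been run in a functional assay on DU-145 cells (Homo sapiens) for antiproliferative activity, read by propidium iodide staining, with a stated time of 96 h (a lower number here means a stronger inhibitor, a higher number a weaker inhibitor), so far. Compound 1 `CC(O)(CSc1cccc(S(F)(F)(F)(F)F)c1)C(=O)Nc1cccc(S(F)(F)(F)(F)F)c1` gives 30300 nM in this assay. Compound 2 `CC(O)(CSc1cccc(C(F)(F)F)c1)C(=O)Nc1cccc(S(F)(F)(F)(F)F)c1` gives 19100 nM in this assay. Compound 3 `CC(O)(COc1cccc(S(F)(F)(F)(F)F)c1)C(=O)Nc1ccc(S(F)(F)(F)(F)F)cc1` gives 29600 nM in this assay.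

Compound 1 and compound 2 differ in one place, (a group of 4 heavy atoms (1 carbon, 3 fluorine; no ring) in place of a group of 6 heavy atoms (5 fluorine, 1 sulfur; no ring), on an aromatic carbon). That change produced a 1.6-fold lower number from compound 1 to compound 2 (0.20 log units; within the scatter), so the two numbers cannot be told apart in this assay. Compound 3 is built on a different core from compound 1; the difference between the two cores is not broken down here, and the values of compound 3 and compound 1 sit close together, both within the scatter of one another and of compound 2.

Compound 4 `CC(O)(COc1cccc(C(F)(F)F)c1)C(=O)Nc1ccc(S(F)(F)(F)(F)F)cc1` has not yet been measured. It is related to compound 3 by a group of 4 heavy atoms (1 carbon, 3 fluorine; no ring) in place of a group of 6 heavy atoms (5 fluorine, 1 sulfur; no ring), on an aromatic carbon. The place description for this change matches word for word the place description for the change from compound 1 to compound 2, so it is the same change, carried onto the core of compound 3.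

Going by the values given here, the only precedent for this change, from compound 1 to compound 2, stayed within the scatter, and nothing in the three measured values suggests the core of compound 3 responds differently. The step from compound 3 to compound 4 is therefore expected to be a 1.5-fold lower number from compound 3 to compound 4 (0.17 log units; within the scatter), essentially the earlier step repeated, because the earlier step was a 1.6-fold lower number from compound 1 to compound 2 (0.20 log units; within the scatter). For compound 4 the estimate in this assay is 20000 nM, with the bulk of repeat measurements expected between 9000 nM and 42000 nM.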

Compound 4, half-maximal inhibitory concentration: 21900 nM
For compound 4 the middle estimate is 1.1-fold (0.04 log units) below the measured one; the range from low to high includes it.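

In this assay, trifluoromethyl in place of pentafluorosulfanyl on the aromatic carbon gives a 1.4-fold lower number from compound 3 to compound 4 (0.13 log units; within the scatter), so on the core of compound 3 this swap leaves the two numbers indistinguishable, as it did on the core of compound 1. Set side by side, the two steps do not differ, and the change reads the same on both cores: the same change on two cores in this assay, a 1.6-fold lower number (0.20 log units; within the scatter) from compound 1 to compound 2 and a 1.4-fold lower number (0.13 log units; within the scatter) from compound 3 to compound 4, 1.2-fold (0.07 log units) apart, within the scatter of two such steps. This shows only that a null result carries over between these two cores; neither step is resolved from the scatter, so the pair gives no measurable effect of the swap that could be said to transfer, and it says nothing about any core beyond these two.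

The compounds shown leave open whether any group at this place moves the number beyond the scatter, since only trifluoromethyl and pentafluorosulfanyl appear there, and an amine, a carboxylic acid, a nitrile or a longer chain would test that. The cores of compound 1 and compound 3 also differ in more than one place, so what each of those differences contributes on its own remains unresolved.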